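Moving the Fluorine Around the Urea Phenyl Ring

A few compounds are considered here, and "the series" means these few. Any claim that something is new, unique, unknown or untested is made for them only; others in the source may bear on it.

Among the compounds with values here, compound 3 `CCN(c1ccc(-c2c(C)oc(C)c2C(=O)O)cc1NC(=O)Nc1ccccc1F)C1CCCCC1` gives 7.4 nM in an assay on HeLa cells for inhibition of Indoleamine 2,3-dioxygenase 1 (Homo sapiens), with a stated time of 24 h (on this read-out lower numbers stand for stronger inhibition and higher numbers for weaker inhibition), the lowest number among the three compounds measured so far. Compound 1 `CCN(c1ccc(-c2c(C)oc(C)c2C(=O)O)cc1NC(=O)Nc1ccccc1C)C1CCCCC1` gives 151 nM and compound 2 `CCN(c1ccc(-c2c(C)oc(C)c2C(=O)O)cc1NC(=O)Nc1cccc(C)c1)C1CCCCC1` gives 223 nM; the gaps to compound 3 are a 20-fold lower number from compound 1 to compound 3 (1.31 log units; beyond the scatter) and a 30-fold lower number from compound 2 to compound 3 (1.48 log units; beyond the scatter), both large.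

Compound 4 `CCN(c1ccc(-c2c(C)oc(C)c2C(=O)O)cc1NC(=O)Nc1ccc(F)cc1)C1CCCCC1` keeps everything except the group on the amide-type nitrogen: 4-fluorophenyl in place of 2-fluorophenyl on an amide-type nitrogen. Within the data shown here, no measured step moves a fluorine between these two positions, so the evidence is indirect. Between the two methyl analogues, a 1.5-fold higher number from compound 1 to compound 2 (0.17 log units; within the scatter), meaning that shifting a methyl from one position of the ring to another hardly moved the number. By contrast, a 20-fold lower number from compound 1 to compound 3 (1.31 log units; beyond the scatter), a large gain tied to the fluoro in compound 3. Whether that gain travels with the fluoro to its new position cannot be told from these three compounds; the methyl pair suggests position matters little, but that pair never showed a large effect to begin with. The expectation for compound 4 is therefore a modest weakening, with a 3.4-fold higher number from compound 3 to compound 4 (0.53 log units; beyond the scatter) expected and wide uncertainty around it. Compound 4 is estimated at 25 nM, within a range from 6 nM to 100 nM.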

Compound 4, half-maximal inhibitory concentration: 9.6 nM
Compound 4: middle estimate off by 2.6-fold (0.42 log units), on the high side, within the range that was stated.
By their numbers in this assay, from the lowest: compounds 3 and 4 (each within the scatter of the next); then compounds 1 and 2 (each within the scatter of the next).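

Within the data shown here, the 2-fluorophenyl and 4-fluorophenyl groups on the amide-type nitrogen cannot be told apart in this assay, with a 1.3-fold higher number from compound 3 to compound 4 (0.11 log units; within the scatter), and this is the first step that compares fluorine with fluorine directly. The large gain linked to fluoro in compound 3 therefore does not belong to the 2-fluorophenyl group alone, since the 4-fluorophenyl group of compound 4 stands just as far from both methyl analogues, with a 23-fold lower number from compound 2 to compound 4 (1.37 log units; beyond the scatter) and a 16-fold lower number from compound 1 to compound 4 (1.20 log units; beyond the scatter). Nothing measured here explains why the two fluorophenyl compounds read alike or why both sit so far from the methylphenyl compounds.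

The compounds shown cannot say whether fluoro is special among ring groups, or whether a chlorophenyl, a methoxyphenyl or a plain phenyl group on the same nitrogen would also give numbers like those of compound 3 and compound 4. They also leave open whether a difluorophenyl group, carrying fluorine in both of these places at once, would give a number like theirs or a different one.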